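The source may hold more compounds than are shown below. What is called first, only, known or untested is meant among the compounds shown, and "the series" means these compounds.

Measured in an ADME assay on 2209-23 cells (Homo sapiens) for cytotoxicity, read by WST assay and thymidine incorporation; a lower number here means that less compound is tolerated, a higher number that more compound is tolerated:
- Compound 1 `CC1=C(C2=C(O)[C@H](C(C)(C)C)N(Cc3ccc(F)cc3)C2=O)Nc2ccc(NS(C)(=O)=O)cc2S1(=O)=O`: > 50000 nM, a limit.
- Compound 2 `CC(C)(C)[C@H]1C(O)=C(C2=CS(=O)(=O)c3cc([N+](=O)[O-])ccc3N2)C(=O)N1Cc1ccc(F)cc1`: > 50000 nM, a limit.
- Compound 3 `Cc1cc(CN2C(=O)C(C3=CS(=O)(=O)c4cc(NS(C)(=O)=O)ccc4N3)=C(O)[C@@H]2C(C)(C)C)ccc1F`: > 50000 nM, a limit.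

No numerical value is available for this series, and (the limit of > 50000 nM in this assay, at which 3 of the 3 values shown sit). Compound 3 therefore has only its limit of > 50000 nM.

Compound 4 `CC(C)CCN1C(=O)C(C2=CS(=O)(=O)c3cc(NS(C)(=O)=O)ccc3N2)=C(O)[C@@H]1C(C)(C)C` has isobutyl in place of 4-fluoro-3-methylphenyl on a saturated chain carbon bound to an amide-type nitrogen in a ring.

For the measured compounds named here, no step between measured compounds is available as a guide. The expected change is a number no higher from compound 3 to compound 4 (the limit leaves the size open), with no shift in either direction expected beyond the scatter in this assay. This expectation rests on compound 3 at > 50000 nM, a limit. For compound 4 the estimate is 50000 nM, expected within 20000 nM to 100000 nM.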

Compound 4, half-maximal cytotoxic concentration: > 50000 nM
Compound 4: no number, only a limit (the forecaster's own chance of this, stated with the estimate: 85%); the middle value sits exactly at the limit.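

For the compounds shown here, compound 3 and compound 4 both give only a limit in this assay, so no step between them can be read. The compounds shown leave open at what concentration any of them becomes cytotoxic, and whether isobutyl in place of 4-fluoro-3-methylphenyl changes that concentration.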